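The compounds below may be only part of what the source reports. "The series", "measured", "known", "first", "only" and "open" are said of these compounds alone.

Compound 1 `CCOC(=O)N(C)CC#CCn1ccnc1` and compound 2 `CCOC(=O)N(C)CC#CCn1cncc1C` share one core and differ in a single place: methyl in place of hydrogen on an aromatic carbon. In a functional assay on the whole organism for agonist activity, with Mus musculus as the target (on this read-out lower numbers stand for an effect already at smaller amounts and higher numbers for an effect only at larger amounts of compound), compound 1 reaches only a limit of the assay, > 100 mg/kg. Compound 1 thus sits at the limit of > 100 mg/kg in this assay, at which 1 of the 3 values shown sits. In this assay compound 2 gives 97 mg/kg. The step that results is an at least 1.0-fold lower number from compound 1 to compound 2 (0.01 log units; that floor lies within the scatter), so the methyl brought no clear change here.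

Compound 3 `O=C1OCCN1CC#CCn1ccnc1` is built on a different core, and in this assay compound 3 gives 3 mg/kg. How the core of compound 3 differs from the core of compound 1 is not broken down here.

Compound 4 `Cc1cncn1CC#CCN1CCOC1=O` has not been measured. It differs from compound 3 in the same way as compound 2 differs from compound 1: methyl in place of hydrogen on an aromatic carbon. Because an at least 1.0-fold lower number from compound 1 to compound 2 (0.01 log units; that floor lies within the scatter) lies within the scatter, a small step is expected here as well. Compound 4 is therefore estimated to give about 3 mg/kg in this assay, between 1.2 mg/kg and 8 mg/kg. The expected step is no change at the digits printed from compound 3 to compound 4 (within the scatter).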

Compound 4, dose for half-maximal effect: 30 mg/kg
Compound 4: the middle estimate sits 10-fold (1.00 log units) below what was measured; the measured number lies above the stated range.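

In this assay, putting methyl in place of hydrogen on an aromatic carbon of the core of compound 3 gives a 10-fold higher number from compound 3 to compound 4 (1.00 log units; beyond the scatter), so on this core a clearly larger dose is needed for the same effect. The same change therefore cannot be assumed to behave alike on both cores, and what it did on one core did not predict what it did on the other: the same change on two cores in this assay, an at least 1.0-fold lower number (0.01 log units; that floor lies within the scatter) from compound 1 to compound 2 and a 10-fold higher number (1.00 log units; beyond the scatter) from compound 3 to compound 4, at least 10-fold (1.01 log units) apart, beyond the scatter of two such steps

These results do not show why the two cores respond differently, and the size of the first step stays uncertain, as compound 1 carries a limit of the assay rather than a number: the limit of > 100 mg/kg in this assay, at which 1 of the 4 values shown sits.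

The compounds shown leave open whether a different group on the same aromatic carbon, such as ethyl, chlorine or hydroxymethyl, would follow the methyl on the core of compound 3. They also leave open how the methyl would behave on a third core, since a comparison of two cores cannot establish a wider rule for the series.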